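Working notes on a shared-core amine series

A few compounds are considered here, and "the series" means these few. Any claim that something is new, unique, unknown or untested is made for them only; others in the source may bear on it.

Measured so far in a functional assay on HTB-54 cells (Homo sapiens) for cytotoxicity, read by MTT assay, with a stated time of 72 h; a higher number here means a weaker inhibitor of growth, a lower number a stronger inhibitor of growth:
- compound 1 `CSc1ccc(CNc2nc(SC)nc3ncccc23)cc1`: 14800 nM
- compound 2 `[SeH]c1nc(NCc2ccccc2)c2cccnc2n1`: > 100000 nM
- compound 3 `CSc1nc(NCCCCCO)c2cccnc2n1`: > 100000 nM

Compound 2 reaches only a limit of this assay, > 100000 nM. Compound 3 likewise returns only a limit, > 100000 nM. Going by the values given here, compound 3 therefore stands at the limit of > 100000 nM in this assay, at which 2 of the 3 values shown sit, and the sole numbered value in the set belongs to compound 1, which gives 14800 nM.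

Compound 4 `CSc1nc(NCc2ccccc2)c2cccnc2n1` differs from compound 3 by phenyl in place of 4-hydroxybutyl on a saturated chain carbon bound to a nitrogen on an aromatic ring. Among the compounds with values here, no step between measured compounds is available to gauge it. Compound 1 carries a benzyl-type amine on the same core and gives a measured number, whereas compound 3 with its 4-hydroxybutyl group sits at the limit; the phenyl entry is therefore expected to move growth inhibition toward stronger values, beyond the scatter, by an at least 3.3-fold lower number from compound 3 to compound 4 (0.52 log units; beyond the scatter). Compound 4 is estimated at 30000 nM, within 8000 nM to 150000 nM.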

Compound 4, concentration for total growth inhibition: 51600 nM
Compound 4: the middle estimate sits 1.7-fold (0.24 log units) below what was measured; measured number inside the range.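

In this assay, phenyl in place of 4-hydroxybutyl on a saturated chain carbon bound to a nitrogen on an aromatic ring gives an at least 1.9-fold lower number from compound 3 to compound 4 (0.28 log units; that floor lies within the scatter), and methylsulfanyl in place of one selenium atom on an aromatic carbon gives an at least 1.9-fold lower number from compound 2 to compound 4 (0.28 log units; that floor lies within the scatter); both are floors only, and the true size of each change stays hidden: the limit of > 100000 nM in this assay, at which 2 of the 4 values shown sit.
Hydrogen in place of methylsulfanyl on an aromatic carbon gives a 3.5-fold higher number from compound 1 to compound 4 (0.54 log units; beyond the scatter), the only step here with a number at both ends.
Open, on these data alone, is how an amine or a carboxylic acid on that aromatic carbon would read.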